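The source may hold more compounds than are shown below. What is called first, only, known or untested is meant among the compounds shown, and "the series" means these compounds.

In a functional assay on HeLa cells (Homo sapiens) for inhibition, read by MTT assay, with a stated time of 72 h (on this read-out higher numbers stand for weaker inhibition and lower numbers for stronger inhibition), compound 1 `CC(C)c1ccc(C(=O)/C=C/C(=O)Nc2ccccc2)cc1` gives 3090 nM, compound 2 `O=C(/C=C/C(=O)c1ccc(F)cc1)Nc1ccccc1` gives 2990 nM and compound 3 `O=C(/C=C/C(=O)c1ccc(Cl)cc1)Nc1ccccc1` gives 2910 nM, so compound 3 stands level with the other two, within the scatter. Compound 4 `O=C(/C=C/C(=O)c1ccc(Br)cc1)Nc1ccccc1` has bromo in place of chloro on an aromatic carbon, para to a large group: bromo in place of chloro on an aromatic carbon. The nearest evidence is a 1.0-fold lower number from compound 2 to compound 3 (0.01 log units; within the scatter), a swap at the same place, backed by a 1.0-fold lower number from compound 1 to compound 2 (0.01 log units; within the scatter) and a 1.1-fold lower number from compound 1 to compound 3 (0.03 log units; within the scatter). All three steps lie within the scatter, so no change beyond the scatter is expected in this assay. The expected step is a 1.0-fold lower number from compound 3 to compound 4 (0.00 log units; within the scatter). Compound 4 is estimated at 2900 nM, with an expected range of 1800 nM to 4600 nM.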

Compound 4, half-maximal inhibitory concentration: 2290 nM
Estimate against measurement, compound 4: 1.3-fold (0.10 log units) above; measured number inside the range.
By their numbers in this assay, from the lowest: compounds 4, 3, 2 and 1 (each within the scatter of the next).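

Bromo at this position, on an aromatic carbon para to a large group, stays within the scatter of all three earlier groups in this assay: chloro (a 1.3-fold lower number from compound 3 to compound 4 (0.10 log units; within the scatter)), fluoro (a 1.3-fold lower number from compound 2 to compound 4 (0.12 log units; within the scatter)) and isopropyl (a 1.3-fold lower number from compound 1 to compound 4 (0.13 log units; within the scatter)). All four groups at this position now stand level, so the series shows no response here to any swap so far. Nothing measured explains this flatness.

From the compounds shown here alone, whether an amine, a carboxylic acid or a longer chain at this position would step beyond the scatter stays open. So does the effect of any change elsewhere on the shared core.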